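Sulfonyl aryl change in the quinoline sulfone series

The source may report more compounds than this note shows. Statements on the series, on what has been measured and on what is new or still open speak of the compounds shown alone.

Going by the values given here, compound 2 `COc1ccc(-c2c(S(=O)(=O)c3ccc(F)cc3)cnc3cc(F)ccc23)cc1` is one of three compounds measured in an ADME assay on microsomes from liver (Homo sapiens) for metabolic stability, tested at 2.5 uM; on this read-out lower numbers stand for slow clearance and higher numbers for fast clearance; in this assay compound 2 gives 1.77 mL/min. Compound 1 `O=S(=O)(c1ccc(F)cc1)c1cnc2cc(F)ccc2c1-c1cccc(F)c1` gives 0.95 mL/min in this assay, and compound 3 `O=S(=O)(c1ccc(F)cc1)c1cnc2cc(F)ccc2c1-c1ccc(Cl)cc1` gives 1.23 mL/min. The step from compound 1 to compound 2 is a 1.9-fold higher number from compound 1 to compound 2 (0.27 log units; within the scatter), and the step from compound 2 to compound 3 is a 1.4-fold lower number from compound 2 to compound 3 (0.16 log units; within the scatter); compound 1 and compound 3 differ by a 1.3-fold higher number from compound 1 to compound 3 (0.11 log units; within the scatter). The three numbers therefore cannot be ranked.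

Compound 4 `COc1ccc(-c2c(S(=O)(=O)c3cc(Cl)cc(Cl)c3)cnc3cc(F)ccc23)cc1` is not yet measured in this assay. It differs from compound 2 by 3,5-dichlorophenyl in place of 4-fluorophenyl on a sulfonyl sulfur. Among the compounds with values here, every measured step varies the aryl group on the aromatic carbon and leaves the aryl group on the sulfonyl sulfur untouched, so no measured step bears directly on this change; what the steps do show is that varying an aryl group has so far stayed within the scatter. The step from compound 2 to compound 4 in this assay is expected to be a 1.2-fold higher number from compound 2 to compound 4 (0.09 log units; within the scatter), not beyond the scatter. Compound 4 is estimated at 2.2 mL/min, with a range from 1 mL/min to 4.8 mL/min.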

Compound 4, intrinsic clearance in a liver preparation (reported as CLH), per the amount of preparation that the assay uses: 1 mL/min
The estimate for compound 4 lay 2.2-fold (0.34 log units) above the measured number, and the stated range covers the measured number.
By their numbers in this assay, from the lowest: compounds 1, 4, 3 and 2 (each within the scatter of the next).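

In this assay, 3,5-dichlorophenyl in place of 4-fluorophenyl on a sulfonyl sulfur gives a 1.8-fold lower number from compound 2 to compound 4 (0.25 log units; within the scatter), the first step read at this position. Going by these compounds alone, in this one pair, the aryl group on the sulfonyl sulfur can be exchanged without leaving the scatter, as was seen for the aryl exchanges on the aromatic carbon among the earlier compounds. Nothing available accounts for the size of this step or links it to either aryl group.

On these data alone, whether a group other than an aryl group on the sulfonyl sulfur, such as an amine or a longer alkyl chain, would also stay within the scatter remains open. Also open, as far as these compounds go, is whether the same exchange would stay within the scatter with 3-fluorophenyl or 4-chlorophenyl on the aromatic carbon.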